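Methylsulfonyl in place of (pyridin-3-yl)methyl on compound 3

The compounds below may be only part of what the source reports. "The series", "measured", "known", "first", "only" and "open" are said of these compounds alone.

Compound 1 `Cc1cc(C)cc(S(=O)(=O)c2c(C(=O)N[C@@H]3CCNC3)[nH]c3ccc(Cl)cc23)c1`: 37300 nM
Compound 2 `Cc1cc(C)cc(S(=O)(=O)c2c(C(=O)N[C@H]3CCN(S(C)(=O)=O)C3)[nH]c3ccc(Cl)cc23)c1`: 29900 nM
Compound 3 `Cc1cc(C)cc(S(=O)(=O)c2c(C(=O)NC3CN(Cc4cccnc4)C3)[nH]c3ccc(Cl)cc23)c1`: 36000 nM

In an ADME assay on MT4 cells (Homo sapiens) for cytotoxicity, read by MTT assay, with a stated time of 5 days (on this read-out lower numbers stand for higher toxicity in this test and higher numbers for lower toxicity in this test), compound 3, at 36000 nM, cannot be told apart from the other two compounds, since all three values lie within the scatter of one another. Compound 4 `Cc1cc(C)cc(S(=O)(=O)c2c(C(=O)NC3CN(S(C)(=O)=O)C3)[nH]c3ccc(Cl)cc23)c1` is the next case, and its change is methylsulfonyl in place of (pyridin-3-yl)methyl on an amine nitrogen in a ring. In words, this is methylsulfonyl in place of (pyridin-3-yl)methyl on an amine nitrogen in a ring.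

Among the measured compounds shown here, no measured step makes exactly this change. The closest is a 1.2-fold higher number from compound 2 to compound 3 (0.08 log units; within the scatter), which exchanges 1-(methylsulfonyl)pyrrolidin-3-yl for 1-((pyridin-3-yl)methyl)azetidin-3-yl. The other two are a 1.2-fold lower number from compound 1 to compound 2 (0.10 log units; within the scatter) and a 1.0-fold lower number from compound 1 to compound 3 (0.02 log units; within the scatter). All three stay within the scatter, so the three substituents tried so far on the amide-type nitrogen have not moved the number. Compound 2, which carries methylsulfonyl, gives 29900 nM, and this supports expecting no shift beyond the scatter.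

The expected change is a 1.1-fold lower number from compound 3 to compound 4 (0.04 log units; within the scatter). Compound 4 is estimated at 33000 nM, with an expected range from 18000 nM to 60000 nM.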

Compound 4, half-maximal cytotoxic concentration: > 252000 nM
Compound 4: no number, only a limit; the forecaster's own chance of this, stated with the estimate: 15%; middle value at least 7.6-fold (0.88 log units) away from the limit.
By their numbers in this assay, from the lowest: compounds 2, 3 and 1 (each within the scatter of the next). At a limit, above all of these: compound 4.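

In this assay, compound 4 gives no number, only a limit of the assay: the limit of > 252000 nM in this assay, at which 1 of the 4 values shown sits.

Methylsulfonyl in place of (pyridin-3-yl)methyl on the amine nitrogen of the four-membered ring gives an at least 7.0-fold higher number from compound 3 to compound 4 (0.84 log units; beyond the scatter), which shows that the read-out can move with this change, something the earlier steps, all within the scatter, did not show. Compound 2 also carries methylsulfonyl, yet 1-(methylsulfonyl)azetidin-3-yl in place of 1-(methylsulfonyl)pyrrolidin-3-yl gives an at least 8.4-fold higher number from compound 2 to compound 4 (0.92 log units; beyond the scatter), and in place of pyrrolidin-3-yl it gives an at least 6.7-fold higher number from compound 1 to compound 4 (0.82 log units; beyond the scatter), so among these compounds the step appears only where methylsulfonyl and the four-membered ring occur together.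

The limit leaves the full size of all three steps open. Also open, going by these compounds, is whether an acetyl group or a plain methyl group on that ring nitrogen would behave like methylsulfonyl or like (pyridin-3-yl)methyl.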